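The source may report more compounds than this note shows. Statements on the series, on what has been measured and on what is new or still open speak of the compounds shown alone.

Measured so far:
- compound 1, `N[C@@H](CC1CCCCC1)CN(C(=O)[C@@H]1C[C@H]1c1ccccc1)c1ccc(-c2ccccc2)cc1`: 1.7 nM
- compound 2, `CC[C@H](C)[C@H](N)CN(C(=O)[C@@H]1C[C@H]1c1cc(F)ccc1F)c1ccc(-c2ccccc2)cc1`: 770 nM

In a functional assay for agonist activity at G protein-coupled receptor 88 (Homo sapiens), read by HTRF and cAMP accumulation (on this read-out higher numbers stand for an effect only at larger amounts of compound and lower numbers for an effect already at smaller amounts), compound 1 gives 1.7 nM, whereas compound 2 gives 770 nM, the higher of the two numbers and separated from compound 1 by far more than the scatter. Going by the values given here, no step between two measured compounds differing in a single place is available, so the size of this kind of change has no measured precedent.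

Compound 3, `CC[C@H](C)[C@H](N)CN(C(=O)[C@@H]1C[C@H]1c1ccoc1)c1ccc(-c2ccccc2)cc1`, is not yet measured. It differs from compound 2 in one place: furan-3-yl in place of 2,5-difluorophenyl on a saturated ring carbon. Among the compounds with values here, with no comparable step on record, the expectation for this assay is a step from compound 2 to compound 3 of a 1.3-fold higher number from compound 2 to compound 3 (0.11 log units; within the scatter), that is, no change beyond the scatter in either direction, with wide uncertainty. Compound 3 is therefore estimated at 1000 nM, in a range from 200 nM to 5000 nM.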

Compound 3, half-maximal effective concentration: 580 nM
Compound 3: the middle estimate sits 1.7-fold (0.24 log units) above what was measured, and the stated range covers the measured number.
By their numbers in this assay, from the lowest: compound 1; then compounds 3 and 2 (each within the scatter of the next).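

In this assay, going by these compounds alone, furan-3-yl in place of 2,5-difluorophenyl on a saturated ring carbon gives a 1.3-fold lower number from compound 2 to compound 3 (0.12 log units; within the scatter), the first step that changes one place only. This position therefore accepts a five-membered aromatic ring with one hetero atom and one hydrogen-bond acceptor in place of a six-membered carbon-only aromatic ring with no acceptor, and the read-out does not separate the two groups. No measured data bear on why the two groups read alike.

Going by these compounds, whether a thiophen-3-yl or a pyridin-3-yl group, or a ring carrying an amine or a carboxylic acid, would read the same at this position remains open. Also open, on these data alone, is whether furan-3-yl would read alike in the rest of the structure of compound 1.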